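Dropping a Methyl from the Hydroxy Amino Acid Side Chain

This account rests on a few compounds, and the source may have more. Where it says the series, first, only, none or still open, it means among the compounds named here.

Compound 1 `CC1=CCC[C@](C)(CC/C(C)=C/CC2=C(O)C(=O)C=C(N[C@@H](C(=O)O)[C@@H](C)O)C2=O)[C@@H]1C` carries an amino acid side chain on the shared core. In an ADME assay on KB cells (Homo sapiens) for cytotoxicity, with a stated time of 48 h (on this read-out higher numbers stand for weaker inhibition and lower numbers for stronger inhibition), compound 1 gives > 10 ug/mL, which is a limit of the assay and not a number. Compound 2 `CC1=CCC[C@](C)(CC/C(C)=C/CC2=C(O)C(=O)C=C(N[C@H](CO)C(=O)O)C2=O)[C@@H]1C` differs from compound 1 by hydrogen in place of methyl on a saturated chain carbon bound to an oxygen on a saturated carbon and a saturated chain carbon. In this assay compound 2 gives > 10 ug/mL, again a limit rather than a number. The step that the two limits leave unreadable from compound 1 to compound 2 therefore cannot be sized, because both values sit at the limit of > 10 ug/mL in this assay, at which 3 of the 3 values shown sit. Compound 3 `C=C1[C@H](C)CCC[C@]1(C)CC/C(C)=C/CC1=C(O)C(=O)C=C(N[C@H](C(=O)O)[C@H](C)O)C1=O` shares the same atoms as compound 1 joined differently; the difference between the two cores is not broken down here. In this assay compound 3 gives > 10 ug/mL, a limit and not a number. Compound 4 `C=C1[C@H](C)CCC[C@]1(C)CC/C(C)=C/CC1=C(O)C(=O)C=C(N[C@@H](CO)C(=O)O)C1=O` differs from compound 3 by hydrogen in place of methyl on a saturated chain carbon bound to an oxygen on a saturated carbon and a saturated chain carbon, the same kind of change as that from compound 1 to compound 2, with the place described in the same words. Since that earlier change left both compounds at the limit, compound 4 is expected to follow, with an expected step that the limit leaves unreadable from compound 3 to compound 4. Compound 4 is estimated at 20 ug/mL, most likely reported only as a limit.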

Compound 4, half-maximal inhibitory concentration: > 10 ug/mL
Compound 4 gave a limit, no number (the forecaster's own chance of this, stated with the estimate: 85%); the middle value does not contradict the limit.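

The change from compound 3 to compound 4 cannot be sized, and neither can any other step here, as every compound stops at a limit of the assay rather than a number: (the limit of > 10 ug/mL in this assay, at which 4 of the 4 values shown sit). What the compounds shown leave open is how strongly any of them acts in this assay and whether 1-hydroxyethyl or hydroxymethyl makes any difference there.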